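The compounds below may be only part of what the source reports. "The series", "measured", "known", "first", "only" and "open" are said of these compounds alone.

Compound 1 `FC(F)(F)c1cccc(/C=C\c2cc3ccccc3nc2Cl)c1` and compound 2 `FC(F)(F)c1cc(/C=C\c2cc3ccccc3nc2Cl)cc(C(F)(F)F)c1` share one core and differ only in one group. In a functional assay on HeLa cells (Homo sapiens) for antiproliferative activity, read by sulforhodamine B assay, with a stated time of 72 h (a higher number here means a weaker inhibitor, a lower number a stronger inhibitor), compound 2 gives 6780 nM and compound 1 gives 2850 nM. That step, a 2.4-fold lower number from compound 2 to compound 1 (0.38 log units; beyond the scatter), is hydrogen in place of trifluoromethyl on an aromatic carbon.

Compound 3 `COc1ccc2nc(Cl)c(/C=C\c3ccc(C(F)(F)F)cc3C(F)(F)F)cc2c1` has a different core; the difference between the two cores is not broken down here. In this assay compound 3 gives only a limit, > 50000 nM, because the assay goes no further than the limit of > 50000 nM in this assay, at which 1 of the 3 values shown sits.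

Compound 4 `COc1ccc2nc(Cl)c(/C=C\c3ccccc3C(F)(F)F)cc2c1` is made from compound 3 by the same kind of change, (hydrogen in place of trifluoromethyl on an aromatic carbon), though here the place is para to a large group, where in compound 1 it was meta to a large group.

On these data alone, the size expected from compound 3 to compound 4, an at least 1.6-fold lower number from compound 3 to compound 4 (0.22 log units; that floor lies within the scatter), rests on the measured step from compound 2 to compound 1, a 2.4-fold lower number from compound 2 to compound 1 (0.38 log units; beyond the scatter), but the starting point is a limit, so where compound 3 truly sits is unknown. Compound 4 is therefore estimated at 30000 nM, within 8000 nM to 120000 nM.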

Compound 4, half-maximal inhibitory concentration: 2600 nM
The estimate for compound 4 lay 12-fold (1.06 log units) above the measured number; measured number outside the range, below it.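

In this assay the new step, an at least 19-fold lower number from compound 3 to compound 4 (1.28 log units; beyond the scatter), is the same change as the earlier one and points the same way, but its size does not carry over: the same change on two cores in this assay, a 2.4-fold lower number (0.38 log units; beyond the scatter) from compound 2 to compound 1 and an at least 19-fold lower number (1.28 log units; beyond the scatter) from compound 3 to compound 4, at least 8.0-fold (0.90 log units) apart, beyond the scatter of two such steps So swapping trifluoromethyl for hydrogen lowered the number on both cores, yet a step measured on one core gave a poor guide to its size on the other, and the change also sits at a different place on the ring in the two pairs, so these data cannot say whether the core or the place sets the gap. The new step is also only a floor, since compound 3 has a limit and not a measured number: the limit of > 50000 nM in this assay, at which 1 of the 4 values shown sits.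

Whether the change would go the same way on a third core remains open, as does what the core alone contributes, since no two compounds shown differ only there. Also open, on these data alone, is how an amine or a carboxylic acid would compare with hydrogen and trifluoromethyl at this place.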